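The source may hold more compounds than are shown below. What is called first, only, known or untested is meant among the compounds shown, and "the series" means these compounds.

Measured so far:
- compound 1, `CCCn1c(=O)c2nc(-c3cnn(Cc4ccc(F)cc4F)c3)[nH]c2n(CCC)c1=O`, 700 nM
- compound 2, `CCCn1c(=O)c2nc(-n3cccn3)[nH]c2n(CCC)c1=O`, > 5800 nM (a limit of the assay, not a number)
- compound 3, `CCCn1c(=O)c2nc(-c3cnn(Cc4ccccc4C(F)(F)F)c3)[nH]c2n(CCC)c1=O`, 37 nM

All values are from an in vitro assay on HEK293 cells for displacement of a labelled ligand from adenosine receptor A2b (Homo sapiens); a lower number here means a stronger inhibitor, a higher number a weaker inhibitor. Compound 2 reaches only the limit described by the limit of > 5800 nM in this assay, at which 1 of the 3 values shown sits. Compound 3 holds the lowest of the two numbers; the nearest is compound 1, which is connected to it by a 19-fold lower number from compound 1 to compound 3 (1.28 log units; beyond the scatter), a large step.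

Compound 4, `CCCn1c(=O)c2nc(-c3cnn(Cc4ccccc4C)c3)[nH]c2n(CCC)c1=O`, is not yet measured. It differs from compound 3 by methyl in place of trifluoromethyl on an aromatic carbon. Going by the values given here, no measured step bears directly on this change; the only step, from compound 1 to compound 3, alters the substitution pattern of the phenyl ring, not a single ortho group. The number for compound 4 is therefore expected to stay close to that of compound 3, with a possible modest rise: a 3.0-fold higher number from compound 3 to compound 4 (0.47 log units; beyond the scatter), estimated at 110 nM within 35 nM to 350 nM.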

Compound 4, inhibition constant: 33 nM
Compound 4: middle estimate off by 3.3-fold (0.52 log units), on the high side; measured number below the stated range.
By their numbers in this assay, from the lowest: compounds 4 and 3 (each within the scatter of the next); then compound 1. At a limit, above all of these: compound 2.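

At this aromatic carbon, methyl and trifluoromethyl cannot be told apart by their numbers (a 1.1-fold lower number from compound 3 to compound 4 (0.05 log units; within the scatter)), so the fluorine atoms of trifluoromethyl are not required for a number in this range. The large gain over the 2,4-difluorophenyl of compound 1 also persists with 2-methylphenyl (a 21-fold lower number from compound 1 to compound 4 (1.33 log units; beyond the scatter)). No measurement shown gives a cause for either step.

Open, from the compounds shown here alone, is whether chlorine, methoxy or ethyl at this aromatic carbon keeps the number in this range. Also open, going by these compounds, is how an unsubstituted phenyl ring compares.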